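The source may hold more compounds than are shown below. What is called first, only, known or untested is meant among the compounds shown, and "the series" means these compounds.

Of the compounds shown here, three sharing one core have been measured in an assay for inhibition of 15-hydroxyprostaglandin dehydrogenase [NAD(+)] (Homo sapiens), read by fluorescence, with a stated time of 15 min, in the presence of a further agent that is not named here; on this read-out lower numbers stand for stronger inhibition and higher numbers for weaker inhibition. Compound 1, `CCCC[S+]([O-])c1sc2nc(-c3nccs3)cc(-c3ccc(C(=O)N(C)C)cc3)c2c1N`, gives 5.9 nM. Compound 2, `CCCC[S+]([O-])c1sc2nc(-c3nccs3)cc(-c3ccc(CNC(C)=O)cc3)c2c1N`, gives 2.5 nM, and compound 3, `CCCC[S+]([O-])c1sc2nc(-c3nccs3)cc(-c3ccc(CO)cc3)c2c1N`, gives 2.5 nM. Replacing the dimethylcarbamoyl with an acetamidomethyl produced a 2.4-fold lower number from compound 1 to compound 2 (0.37 log units; beyond the scatter), and replacing it with a hydroxymethyl produced a 2.4-fold lower number from compound 1 to compound 3 (0.37 log units; beyond the scatter). Between the two smaller substituents there was no change at the digits printed from compound 2 to compound 3 (within the scatter). Compound 3 thus stands level with compound 2 at the digits shown, the two together giving the lowest numbers of the three, with compound 1 the furthest away.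

Compound 4, `CCCC[S+]([O-])c1sc2nc(-c3nccs3)cc(-c3ccc(COC(=O)NCC)cc3)c2c1N`, differs from compound 3 by ethylcarbamoyl in place of hydrogen on an oxygen on a saturated carbon. The step that bears most directly on it is the exchange at the same chain carbon between compound 2 and compound 3, which lay within the scatter, while the two steps from compound 1 were only modest. The groups tried at this position have all fallen within a narrow band, so the expected step of a 1.3-fold higher number from compound 3 to compound 4 (0.11 log units; within the scatter) is small, and no movement beyond the scatter is anticipated. Compound 4 is therefore expected to give 3.2 nM, with a range from 1.3 nM to 8 nM.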

Compound 4, half-maximal inhibitory concentration: 3.4 nM
Compound 4: middle estimate off by 1.1-fold (0.03 log units), on the low side; low and high end bracket the measured number.
By their numbers in this assay, from the lowest: compounds 2, 3, 4 and 1 (each within the scatter of the next, the first and the last beyond it).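

In this assay, ethylcarbamoyl in place of hydrogen on the oxygen of compound 3 adds 5 heavy atoms, yet the result is only a 1.4-fold higher number from compound 3 to compound 4 (0.13 log units; within the scatter) and this position therefore tolerates a much larger group than the earlier compounds had shown. The change from acetamido to (ethylcarbamoyl)oxy on the same saturated chain carbon gives a 1.4-fold higher number from compound 2 to compound 4 (0.13 log units; within the scatter) and so also stays inside the narrow band. Unlike compound 2 and compound 3, which each stand beyond the scatter of compound 1, the new compound does not, since the step is a 1.7-fold lower number from compound 1 to compound 4 (0.24 log units; within the scatter) and it lies within the scatter of all three earlier compounds.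

Nothing available here explains why so large an addition leaves the number within the scatter. Still open, from the compounds shown here alone, is whether a carboxylic acid or an aminomethyl group in place of the hydroxymethyl, or a propyl or longer chain in place of the ethyl on the carbamoyl nitrogen, would take the number in this assay beyond the scatter.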